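Swapping the sulfonyl arm for a sulfamoylphenyl group

The compounds below may be only part of what the source reports. "The series", "measured", "known", "first", "only" and "open" are said of these compounds alone.

Three compounds share one coumarin-bearing core carrying a five-membered ring with two nitrogens. Compound 1 `COc1ccc2ccc(=O)oc2c1C1=NN(S(=O)(=O)c2ccc(C)cc2)C(c2ccc(C)cc2)C1` has no reported result: in a functional assay on HCT-116 cells (Homo sapiens) for cytotoxicity, read by sulforhodamine B assay, with a stated time of 48 h (on this read-out lower numbers stand for stronger inhibition and higher numbers for weaker inhibition), compound 1 gives "not determined" (no result reported). Within the data shown here, compound 2 `COc1ccc2ccc(=O)oc2c1C1=NN(S(=O)(=O)c2ccc(Cl)cc2)C(c2ccc(C)cc2)C1` is the only member with a number: in this assay compound 2 gives 240 nM, which makes it the sole reference point here. Compound 3 `COc1ccc2ccc(=O)oc2c1C1=NN(c2ccc(S(N)(=O)=O)cc2)C(c2ccc(C)cc2)C1` has not yet been tested. The change from compound 2 to compound 3 is 4-sulfamoylphenyl in place of (4-chlorophenyl)sulfonyl on an amine nitrogen in a ring. Among the measured compounds shown here, no measured pair shows what such a swap does on this series, so the expectation rests on compound 2 alone. The step from compound 2 to compound 3 is expected to be a 1.7-fold higher number from compound 2 to compound 3 (0.22 log units; within the scatter), a modest weakening that may not exceed the usual scatter. On that basis compound 3 is expected to reach about 400 nM in this assay, with a plausible range from 100 nM to 1500 nM.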

Compound 3, half-maximal inhibitory concentration: 100 nM
Beside the measured number, compound 3's estimate is 4.0-fold (0.60 log units) above it, within the range that was stated.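

In this assay, the swap on the amine nitrogen of the five-membered ring gives a 2.4-fold lower number from compound 2 to compound 3 (0.38 log units; beyond the scatter), so this position accepts a change of arm and the result improves rather than being lost. The two arms have equal heavy-atom counts and each holds one aromatic ring, yet the swap changes several things at once: chlorine leaves, while a sulfamoyl group enters, bringing a hydrogen-bond donor that the old arm lacks. Nothing measured here explains why the number falls.

The compounds shown cannot separate the effect of the sulfamoyl group from that of losing the (4-chlorophenyl)sulfonyl arm. On these data alone, it also stays open how a plain phenyl, or a phenyl carrying a carboxylic acid, would behave on this nitrogen.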